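The source may report more compounds than this note shows. Statements on the series, on what has been measured and on what is new or still open speak of the compounds shown alone.

Measured compounds:
- compound 1, `CC(c1ccc(-c2ccccc2)c(F)c1)c1nnc2n1N=C(c1ccc(Cl)cc1)CS2`: 3800 nM
- compound 2, `CC(C)Cc1ccc(C(C)c2nnc3n2N=C(c2ccc(Br)cc2)CS3)cc1`: 8300 nM

In a functional assay on Hep 3B2 cells (Homo sapiens) for inhibition, read by sulforhodamine B assay, with a stated time of 72 h (on this read-out higher numbers stand for weaker inhibition and lower numbers for stronger inhibition), compound 1 holds the lower of the two numbers; compound 2 gives a number that is higher, and the two compounds differ in more than one place, so only their values are compared here. Compound 3, `CC(c1ccc(-c2ccccc2)c(F)c1)c1nnc2n1N=C(c1ccc([N+](=O)[O-])cc1)CS2`, is yet to be measured. It differs from compound 1 by nitro in place of chloro on an aromatic carbon, the 4-chlorophenyl becoming 4-nitrophenyl. Going by the values given here, no measured pair shows this change, so the step is expected to be modest, in either direction or none beyond the scatter, as a 1.1-fold higher number from compound 1 to compound 3 (0.02 log units; within the scatter). Compound 3 is therefore estimated at 4000 nM, within 1500 nM to 12000 nM.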

Compound 3, half-maximal inhibitory concentration: 2900 nM
For compound 3 the middle estimate is 1.4-fold (0.14 log units) above the measured one; low and high end bracket the measured number.
By their numbers in this assay, from the lowest: compounds 3 and 1 (each within the scatter of the next); then compound 2.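

In this assay the 4-chlorophenyl of compound 1 becomes the 4-nitrophenyl of compound 3 with a 1.3-fold lower number from compound 1 to compound 3 (0.12 log units; within the scatter) and so this position, para to a large group, accepts nitro in place of chloro without a step beyond the scatter. The larger group, with three heavy atoms against one and two hydrogen-bond acceptors against none, leaves the reading where it was. Nothing measured here accounts for this. The compounds shown leave open how an amine, a carboxylic acid or a longer chain would read at this position, and whether nitro and chloro would still read alike with the rest of compound 1 changed.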